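Aryl ether head group: acetyl replaced by methoxy

The source may hold more compounds than are shown below. What is called first, only, known or untested is meant among the compounds shown, and "the series" means these compounds.

Measured in a functional assay (aorta) with Oryctolagus cuniculus as the target; a higher number here means weaker binding, a lower number tighter binding:
compound 1 `COc1cc(C(C)=O)ccc1OCCCN1CCC(C(c2ccc(F)cc2)c2ccc(F)c(F)c2)CC1` gives 1.26 nM
compound 2 `COc1cc(C(C)=O)ccc1OCCCN1CCC(=C(c2ccc(F)cc2)c2ccc(F)cc2)CC1` gives 3.98 nM
compound 3 `CC(=O)c1ccc(OCCCN2CCC(C(c3ccc(F)cc3)c3ccc(F)cc3)CC2)cc1` gives 2.51 nM

Compound 3 stands second highest of the three numbers. Its nearest neighbour is compound 2, a gap within the scatter, and its furthest is compound 1, also within the scatter, so the three values cannot be ordered on these data. Going by the values given here, no measured pair differs in a single place, so no single step is known from this series. Compound 4 `COc1ccc(OCCCN2CCC(C(c3ccc(F)cc3)c3ccc(F)cc3)CC2)cc1` differs from compound 3 as follows: methoxy in place of acetyl on an aromatic carbon. With nothing measured to go by, the expected step, a 1.3-fold higher number from compound 3 to compound 4 (0.11 log units; within the scatter), is small and not beyond the scatter in either direction. Compound 4 is estimated at 3.2 nM in this assay, with a range from 1 nM to 10 nM.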

Compound 4, dissociation constant: 2.51 nM
The estimate for compound 4 lay 1.3-fold (0.11 log units) above the measured number; the measured number falls inside the stated range.
By their numbers in this assay, from the lowest: compounds 1, 3, 4 and 2 (each within the scatter of the next, the first and the last beyond it).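

In this assay, going by these compounds alone, methoxy in place of acetyl on this aromatic carbon, para to a large group, gives no change at the digits printed from compound 3 to compound 4 (within the scatter), the first single-place step. The acetyl carbonyl is therefore not required for this read-out in this pair, since methoxy, with one heavy atom fewer, serves equally well here. No other measurement available bears on why the two groups read alike.

As far as these compounds go, whether an amine or a carboxylic acid at this carbon would also stay within the scatter remains open. So does whether this exchange reads the same on the cores of compound 1 and compound 2.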